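Working notes: from compound 2 to compound 4

The source may hold more compounds than are shown below. What is called first, only, known or untested is meant among the compounds shown, and "the series" means these compounds.

In a functional assay on HCT-116 cells (Homo sapiens) for inhibition, read by colorimetric assay, with a stated time of 3 days (on this read-out lower numbers stand for stronger inhibition and higher numbers for weaker inhibition), compound 2 (`O=C(CCCCCCNC(=O)C(O)(O)C(F)(F)F)Nc1ccc(F)cc1F`) gives 18500 nM. Compound 3 (`COc1cc(NC(=O)CCCCCCNC(=O)C(O)(O)C(F)(F)F)cc(OC)c1OC`) gives 14100 nM, within the scatter of compound 2. Compound 1 (`O=C(CCCCCCNC(=O)C(O)(O)C(F)(F)F)Nc1ncc(-c2ccc(Br)cc2)s1`) gives 2460 nM, a lower number beyond the scatter of compound 2.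

Compound 4 (`CC(=O)c1ccc(NC(=O)CCCCCCNC(=O)C(O)(O)C(F)(F)F)cc1`) carries 4-acetylphenyl in place of 2,4-difluorophenyl on an amide-type nitrogen. For the measured compounds named here, no measured pair isolates a single change. Compound 3, at 14100 nM, has a different group at this place and stays level with compound 2, although compound 1 goes against this. The step of a 1.5-fold lower number from compound 2 to compound 4 (0.19 log units; within the scatter) is therefore expected to be small and not beyond the scatter. For compound 4 the estimated value is 12000 nM, with an expected range of 4500 nM to 28000 nM.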

Compound 4, half-maximal inhibitory concentration: 12100 nM
The estimate for compound 4 lay 1.0-fold (0.00 log units) below the measured number; the range from low to high includes it.
By their numbers in this assay, from the lowest: compound 1; then compounds 4, 3 and 2 (each within the scatter of the next).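

For the compounds shown here, the swap of 4-acetylphenyl for 2,4-difluorophenyl on an amide-type nitrogen gives a 1.5-fold lower number from compound 2 to compound 4 (0.18 log units; within the scatter) in this assay, the first step that isolates a single change. This place therefore accepts the loss of both fluorines and the entry of an acetyl carbonyl without a shift beyond the scatter. No measurement available here explains this result.

Going by these compounds, whether an amine or a carboxylic acid in place of the acetyl group would move the number remains open. On these data alone, the effect of a longer chain in the shared core is also open.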